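Fluoro Added Again, This Time on the Fused Ring

The source may hold more compounds than are shown below. What is called first, only, known or untested is meant among the compounds shown, and "the series" means these compounds.

Compound 1, `COc1cccc(C(=O)NC2CCN(Cc3ccc4ccccc4c3)CC2)c1`: in an assay on isolated protein for binding affinity to melanin-concentrating hormone receptor 1 (Homo sapiens) (a higher number here means a weaker inhibitor, a lower number a stronger inhibitor), compound 1 gives 29 nM.
Compound 2, `COc1cc(OC)cc(C(=O)NC2CCN(Cc3ccc4ccccc4c3)CC2)c1`: in this assay compound 2 gives 27 nM.
Compound 3, `COc1cc(C(=O)NC2CCN(Cc3ccc4ccccc4c3)CC2)ccc1F`: in this assay compound 3 gives 13 nM.

Compound 4, `COc1cc(OC)cc(C(=O)NC2CCN(Cc3ccc4cc(F)ccc4c3)CC2)c1`, has not yet been measured. It differs from compound 2 by fluoro in place of hydrogen on an aromatic carbon. The same kind of change links compound 1 to compound 3: there it reads (fluoro in place of hydrogen on an aromatic carbon), and that step gave a 2.2-fold lower number from compound 1 to compound 3 (0.35 log units; beyond the scatter). The place is not the same, however. In compound 3 the fluoro sits on a six-membered aromatic ring of carbon only, ortho to a methoxy group and para to a large group; in compound 4 it sits on a six-membered aromatic ring of carbon only that is part of a fused or bridged system of two rings, meta to a fused ring and para to a fused ring. The two cores also differ: compound 2 carries methoxy in place of hydrogen on an aromatic carbon relative to compound 1, and that difference gave a 1.1-fold lower number from compound 1 to compound 2 (0.03 log units; within the scatter), so the core change by itself stays within the scatter.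

Because the earlier fluoro step a 2.2-fold lower number from compound 1 to compound 3 (0.35 log units; beyond the scatter) was modest and was made at a place described differently, the step to compound 4 is expected to be small, a 1.4-fold lower number from compound 2 to compound 4 (0.13 log units; within the scatter). Compound 4 is therefore estimated at 20 nM in this assay, with a likely range from 8 nM to 50 nM.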

Compound 4, inhibition constant: 32 nM
Beside the measured number, compound 4's estimate is 1.6-fold (0.20 log units) below it, and the stated range covers the measured number.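

On the core of compound 2, fluoro in place of hydrogen on the fused ring gives a 1.2-fold higher number from compound 2 to compound 4 (0.07 log units; within the scatter), so in this assay this step cannot be told apart from repeat-measurement noise, whereas the earlier fluoro step lay just beyond that noise. The two steps look different at first sight, yet the gap between them is no larger than two such steps can show by chance: the same change on two cores in this assay, a 2.2-fold lower number (0.35 log units; beyond the scatter) from compound 1 to compound 3 and a 1.2-fold higher number (0.07 log units; within the scatter) from compound 2 to compound 4, 2.6-fold (0.42 log units) apart, within the scatter of two such steps. This means the data do not show that the gain seen on the core of compound 1 carries over to the core of compound 2, and they do not show that it fails to carry over either, all the more as the fluoro stands on a different ring in each step, so that the core and the place of the change cannot be separated.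

Going by these compounds, what stays open is how fluoro on the fused ring would read on the core of compound 1, where a direct comparison on a single core would become possible. Also open, on these data alone, is how a chloro, a nitrile or an amine at that same place on the fused ring would read in this assay.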